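Swapping the benzyl substituent on a flavonol cytotoxicity series

A few compounds are considered here, and "the series" means these few. Any claim that something is new, unique, unknown or untested is made for them only; others in the source may bear on it.

Measured compounds:
- compound 1, `Cc1ccccc1COc1c(-c2ccccc2)oc2cc(O)cc(O)c2c1=O`: 55000 nM in an ADME assay on Huh-5-2 cells (Homo sapiens) for cytotoxicity, read by WST assay, with a stated time of 3 days; a higher number here means that more compound is tolerated, a lower number that less compound is tolerated
- compound 2, `O=c1c(OCc2cccc(Br)c2)c(-c2ccccc2)oc2cc(O)cc(O)c12`: 15000 nM in this assay
- compound 3, `O=c1c(OCc2cccc([N+](=O)[O-])c2)c(-c2ccccc2)oc2cc(O)cc(O)c12`: 31000 nM in this assay

Among these three, compound 1 gives the highest number, so the cells tolerate the most of it. Compound 3 sits within the usual scatter of compound 1, so no real difference can be claimed between those two, whereas compound 2 lies clearly lower.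

Compound 4, `O=c1c(OCc2ccc(Cl)cc2)c(-c2ccccc2)oc2cc(O)cc(O)c12`, is not yet measured. Relative to compound 1 its change is 4-chlorophenyl in place of 2-methylphenyl on a saturated chain carbon bound to an oxygen on an aromatic ring. The step most like this one is a 3.7-fold lower number from compound 1 to compound 2 (0.56 log units; beyond the scatter), where a halogen-bearing ring also replaced the 2-methylphenyl at the same place. The step of a 1.8-fold lower number from compound 1 to compound 3 (0.25 log units; within the scatter) stayed within the scatter, and between the two halogen and nitro analogues the step of a 2.1-fold higher number from compound 2 to compound 3 (0.32 log units; beyond the scatter) was modest. Since compound 4 carries a halogen like compound 2, a modest drop in this assay is expected, though in no case with confidence beyond the scatter.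

The expected step is a 2.2-fold lower number from compound 1 to compound 4 (0.34 log units; beyond the scatter). Compound 4 is therefore estimated at 25000 nM, with a likely range from 10000 nM to 60000 nM.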

Compound 4, half-maximal cytotoxic concentration: 36000 nM
Compound 4: the middle estimate sits 1.4-fold (0.16 log units) below what was measured; measured number inside the range.
By their numbers in this assay, from the lowest: compound 2; then compounds 3, 4 and 1 (each within the scatter of the next).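

In this assay the 4-chlorophenyl group on the saturated chain carbon bound to an oxygen on an aromatic ring gives a 1.5-fold lower number from compound 1 to compound 4 (0.18 log units; within the scatter) and, against the nitro-bearing ring, a 1.2-fold higher number from compound 3 to compound 4 (0.06 log units; within the scatter) so at this position compounds 1, 3 and 4 cannot be told apart by their numbers. Among these compounds, a chlorine-bearing ring therefore does not repeat the drop seen with the bromine-bearing ring, and the step of a 2.4-fold higher number from compound 2 to compound 4 (0.38 log units; beyond the scatter) shows that carrying a halogen on this ring is not enough to place a compound with compound 2, which is now the only compound clearly separated from any other. Nothing is available here that explains why compound 2 stands apart from compound 4.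

Compound 2 and compound 4 differ both in which halogen the ring carries and in where it sits on the ring, so the compounds shown cannot say which of these two differences matters. Going by these compounds, how the cells would tolerate a compound with an amine or a carboxylic acid on this ring, or with a longer chain in place of the single chain carbon, also remains open.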